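Swapping the methyl for fluorine on the pendant ring

This account rests on a few compounds, and the source may have more. Where it says the series, first, only, none or still open, it means among the compounds named here.

Compound 1 `Clc1ccc(-c2cn(Cc3ccccc3)c3c2CNCC3)cc1Cl` gives 4470 nM in an assay on HEK293 cells for displacement of a labelled ligand from 5-hydroxytryptamine receptor 7 (Rattus norvegicus), with a stated time of 60 min; a lower number here means a stronger inhibitor, a higher number a weaker inhibitor.
Compound 2 `Clc1ccc(-c2cn(Cc3ccccc3)c3c2CNCC3)c(Cl)c1` gives 2070 nM in this assay.
Compound 3 `Cc1ccc(-c2cn(Cc3ccccc3)c3c2CNCC3)cc1` gives 35 nM in this assay.

Compound 3 stands lowest of the three numbers, with a 59-fold lower number from compound 2 to compound 3 (1.77 log units; beyond the scatter) and a 130-fold lower number from compound 1 to compound 3 (2.11 log units; beyond the scatter) both well beyond the scatter. Compound 4 `Fc1ccc(-c2cn(Cc3ccccc3)c3c2CNCC3)cc1` differs from compound 3 by fluoro in place of methyl on an aromatic carbon, a change sitting on the ring that carries the only variation among all four compounds. For the measured compounds named here, no measured step swaps a single group in this position; the two steps that reach compound 3 each remove two chlorines and add a methyl, so they bear on the new change only loosely, though they show that this ring is sensitive to what sits on it. The dichloro compounds are far weaker, while the methyl compound is the best seen, so a small, single replacement is expected to cost less than those large steps. Compound 4 is therefore expected to move modestly, a 2.3-fold higher number from compound 3 to compound 4 (0.36 log units; beyond the scatter), toward a weaker number. The estimate for compound 4 is 80 nM, within 20 nM to 350 nM.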

Compound 4, inhibition constant: 45 nM
Compound 4: middle estimate off by 1.8-fold (0.25 log units), on the high side; the range from low to high includes it.
By their numbers in this assay, from the lowest: compounds 3 and 4 (each within the scatter of the next); then compound 2; then compound 1.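

Placing fluoro where methyl stood, para to a large group, gives a 1.3-fold higher number from compound 3 to compound 4 (0.11 log units; within the scatter) in this assay, so the two groups cannot be told apart at this position. Fluoro also keeps the wide gap to the dichloro compounds, with a 46-fold lower number from compound 2 to compound 4 (1.66 log units; beyond the scatter) and a 99-fold lower number from compound 1 to compound 4 (2.00 log units; beyond the scatter), so the low number of compound 3 does not depend on the methyl itself. Nothing measured here gives a reason why methyl and fluoro match at this position.

As far as these compounds go, it remains open whether a single chlorine on this carbon would stay close to compound 3 and compound 4 or fall toward compound 1 and compound 2. From the compounds shown here alone, it is equally open whether a methoxy group, an amine or a carboxylic acid at this position would keep the number this low.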